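Imidazole to Fluoropyridine: What Happens to Solubility

The compounds below may be only part of what the source reports. "The series", "measured", "known", "first", "only" and "open" are said of these compounds alone.

Two measured compounds share one core. In a physicochemical assay for solubility, read by HPLC, using the shake flask method, measured as kinetic solubility, with a stated time of 2 h, at pH 7.4 (on this read-out lower numbers stand for lower solubility and higher numbers for higher solubility), compound 1 `Cc1cc(NCc2ccccn2)n2nc(C)c(-c3ccc(F)cc3)c2n1` reports only a limit, < 5000 nM. Compound 2 `Cc1cc(NCc2ncc[nH]2)n2nc(C)c(-c3ccccc3)c2n1` also reports only a limit in this assay, < 5000 nM. Both values sit at the same limit (the limit of < 5000 nM in this assay, at which 2 of the 2 values shown sit), so compound 2 stands where every measured value stands, with no number beneath it. Compound 3 `Cc1cc(NCc2ccc(F)cn2)n2nc(C)c(-c3ccccc3)c2n1` differs from compound 2 in one place: 5-fluoropyridin-2-yl in place of 1H-imidazol-2-yl on a saturated chain carbon bound to a nitrogen on an aromatic ring. Within the data shown here, no measured pair shows the effect of such a change, so the step that the limit leaves unreadable from compound 2 to compound 3 is expected to stay within the scatter or run somewhat lower. Compound 3 is estimated at 2000 nM, between 500 nM and 5000 nM.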

Compound 3, solubility: < 5000 nM
Compound 3 was reported as a limit; the forecaster's own chance of this, stated with the estimate: 85%; the middle value lies beyond the limit too.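

In this assay, among these compounds, compound 2 and compound 3 both give only a limit, so no step between them can be read. From the compounds shown here alone, the actual solubility of each compound, and whether 5-fluoropyridin-2-yl in place of 1H-imidazol-2-yl changes it, stays open.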